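The source may report more compounds than this note shows. Statements on the series, on what has been measured and on what is new or still open speak of the compounds shown alone.

Working notes on a small set built on one shared core.

Compound 1 `CCc1nnc(SCC(=O)c2ccc(C)cc2)n1N1C(=O)c2ccccc2C1=O` carries an ethyl group on the core and a (((4-methylphenyl)carbonyl)methyl)sulfanyl arm. In a functional assay on A549 cells (Homo sapiens) for cytotoxicity, read by MTT assay, with a stated time of 48 h (on this read-out lower numbers stand for stronger inhibition and higher numbers for weaker inhibition), compound 1 gives > 200000 nM, which is a limit of the assay and not a number. Compound 2 `CCc1nnc(SC)n1N1C(=O)c2ccccc2C1=O` differs from compound 1 in the arm only: hydrogen in place of (4-methylphenyl)carbonyl on a saturated chain carbon bound to a sulfur. In this assay compound 2 gives > 200000 nM, again a limit and not a number. For this pair the step is a step that the two limits leave unreadable from compound 1 to compound 2, because both values sit at the limit of > 200000 nM in this assay, at which 2 of the 3 values shown sit.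

Compound 3 `COc1cc(-c2nnc(SCC(=O)c3ccc(C)cc3)n2N2C(=O)c3ccccc3C2=O)cc(OC)c1OC` keeps the arm of compound 1 but differs in the core: 3,4,5-trimethoxyphenyl in place of ethyl on an aromatic carbon. In this assay, going by the values given here, compound 3 gives 6760 nM, the only number among the three measured values. The step of an at least 29-fold lower number from compound 1 to compound 3 (1.47 log units; beyond the scatter) is the one readable movement in the set.

Compound 4 `COc1cc(-c2nnc(SC)n2N2C(=O)c3ccccc3C2=O)cc(OC)c1OC` is not yet measured. It differs from compound 3 by hydrogen in place of (4-methylphenyl)carbonyl on a saturated chain carbon bound to a sulfur, the same change as that from compound 1 to compound 2, at the same place. Since that earlier change left no readable size, the expectation for compound 4 rests on compound 3 alone, at 6760 nM, with wide uncertainty in either direction. For compound 4 in this assay the estimate is 25000 nM. The expected range for compound 4 runs from 5000 nM to 150000 nM. This estimate means an expected step of a 3.7-fold higher number from compound 3 to compound 4 (0.57 log units; beyond the scatter).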

Compound 4, half-maximal inhibitory concentration: > 200000 nM
Compound 4 gave a limit, no number; the forecaster's own chance of this, stated with the estimate: 25%; middle value at least 8.0-fold (0.90 log units) from the limit.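

On the core of compound 3, the loss of (4-methylphenyl)carbonyl from the saturated chain carbon bound to a sulfur gives an at least 29-fold higher number from compound 3 to compound 4 (1.47 log units; beyond the scatter) in this assay, and among the four compounds shown a number appears only where the 3,4,5-trimethoxyphenyl group and the (((4-methylphenyl)carbonyl)methyl)sulfanyl arm stand together. Going by these compounds, compound 4 gives > 200000 nM, which is a limit of the assay and not a number, so the true size of this step stays unknown. The same change on the core of compound 1 cannot be read, so the series shows a large step on one core and gives no measured size on the other, and it does not show whether the change carries the same weight on both, because the values sit at the same limit: the limit of > 200000 nM in this assay, at which 3 of the 4 values shown sit.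

The compounds shown leave open which part of the departing group matters, whether the carbonyl, the aromatic ring or the methyl on that ring. They also leave open how the 3,4,5-trimethoxyphenyl core would respond to other ends on the arm, such as an amine, a carboxylic acid or a longer chain in place of the methylsulfanyl group of compound 4.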